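A second 5-chlorothiophen-2-yl sulfonamide on the shared core

The compounds below may be only part of what the source reports. "The series", "measured", "known", "first", "only" and "open" are said of these compounds alone.

Three compounds share one core and differ only in the groups on their sulfonyl sulfurs. In an assay for inhibition of HSP60/HSP10 (Homo sapiens), with a stated time of 60 min (on this read-out lower numbers stand for stronger inhibition and higher numbers for weaker inhibition), compound 1 `O=S(=O)(Nc1ccc2oc(-c3ccc(NS(=O)(=O)c4cccc5nonc45)cc3)nc2c1)c1ccc(Cl)s1` gives 11000 nM, compound 2 `O=S(=O)(Nc1ccc(-c2nc3cc(NS(=O)(=O)c4ccc(Cl)s4)ccc3o2)cc1)c1ccc(Cl)c(C(F)(F)F)c1` gives 6100 nM, and compound 3 `O=[N+]([O-])c1ccc(S(=O)(=O)Nc2ccc(-c3nc4cc(NS(=O)(=O)c5ccc([N+](=O)[O-])cc5)ccc4o3)cc2)cc1` gives 51000 nM. Compound 2 holds the lowest of these three numbers, yet its gap to compound 1 lies within the scatter; only compound 3 stands clearly apart from it. Compound 4 `O=S(=O)(Nc1ccc(-c2nc3cc(NS(=O)(=O)c4ccc(Cl)s4)ccc3o2)cc1)c1ccc(Cl)s1` carries 5-chlorothiophen-2-yl in place of 4-chloro-3-(trifluoromethyl)phenyl on a sulfonyl sulfur, so that both sulfonyl sulfurs now bear 5-chlorothiophen-2-yl. Going by the values given here, the one measured step at this place, a 1.8-fold lower number from compound 1 to compound 2 (0.26 log units; within the scatter), stayed within the scatter. Compound 4 is therefore expected to show no step beyond the scatter, a 1.3-fold higher number from compound 2 to compound 4 (0.12 log units; within the scatter), in this assay. The estimate for compound 4 is 8000 nM, with a range from 3000 nM to 25000 nM.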

Compound 4, half-maximal inhibitory concentration: 5900 nM
Compound 4: the middle estimate sits 1.4-fold (0.13 log units) above what was measured, and the stated range covers the measured number.
By their numbers in this assay, from the lowest: compounds 4, 2 and 1 (each within the scatter of the next); then compound 3.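

In this assay, the result extends the flat picture at this sulfonyl sulfur: 5-chlorothiophen-2-yl in place of 4-chloro-3-(trifluoromethyl)phenyl gives a 1.0-fold lower number from compound 2 to compound 4 (0.01 log units; within the scatter) and, against the group on compound 1, gives a 1.9-fold lower number from compound 1 to compound 4 (0.27 log units; within the scatter). Thus compounds 1, 2 and 4, with three different groups here, stay within the scatter of one another, and the smaller 5-chlorothiophen-2-yl group matches the larger 4-chloro-3-(trifluoromethyl)phenyl group. Nothing beyond these numbers is available to explain them. Going by these compounds, what a plain thiophen-2-yl or a methyl group on this sulfonyl sulfur would give remains open.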